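This account rests on a few compounds, and the source may have more. Where it says the series, first, only, none or still open, it means among the compounds named here.

Three compounds share one core. Compound 2 `COc1cccc(/C=C2\CCC/C(=C\c3ccc(OC)c(OC)c3)C2=O)c1` gives, in a functional assay on A549 cells (Homo sapiens) for cytotoxicity, read by MTT assay, with a stated time of 72 h (on this read-out lower numbers stand for stronger inhibition and higher numbers for weaker inhibition), 6700 nM. Compound 1 `COc1ccc(/C=C2\CCC/C(=C\c3cccc(OC)c3OC)C2=O)cc1OC` differs by methoxy in place of hydrogen on an aromatic carbon and gives 14400 nM in this assay; the step of a 2.1-fold higher number from compound 2 to compound 1 (0.33 log units; beyond the scatter) weakened it. Compound 3 `COc1ccc(/C=C2\CCC/C(=C\c3ccc(OC)c(OC)c3)C2=O)cc1` has a differently joined core: 4-methoxyphenyl in place of 3-methoxyphenyl on a double-bonded chain carbon bound to a double-bonded ring carbon. For compound 3 this assay reports only a limit, > 20000 nM, so the step of an at least 2.9-fold higher number from compound 2 to compound 3 (0.47 log units; beyond the scatter) is itself bounded. Compound 4 `COc1ccc(/C=C2\CCC/C(=C\c3ccc(OC)c(OC)c3)C2=O)c(OC)c1` is not yet measured; it differs from compound 3 by methoxy in place of hydrogen on an aromatic carbon, the same kind of change as from compound 2 to compound 1, though the entering methoxy sits meta to a methoxy group rather than ortho to one. Since compound 3 already rests at the limit of > 20000 nM in this assay, at which 1 of the 3 values shown sits, compound 4 is expected to give 35000 nM. The expected step that the limit leaves unreadable from compound 3 to compound 4 would likely again be a limit, within an expected range of 15000 nM to 90000 nM.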

Compound 4, half-maximal inhibitory concentration: > 20000 nM
Compound 4: only a limit was reported; the forecaster's own chance of this, stated with the estimate: 70%; the middle value lies beyond the limit too.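

For the compounds shown here, compound 3 and compound 4 each give only a limit, so no step between them can be read: the limit of > 20000 nM in this assay, at which 2 of the 4 values shown sit.

In this assay, on these data alone, it stays open whether methoxy in place of hydrogen on compound 3 changes the true value at all.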